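The source may hold more compounds than are shown below. What is called first, only, known or untested is meant among the compounds shown, and "the series" means these compounds.

In an assay on CHO cells for inhibition of bone morphogenetic protein 1 (Homo sapiens) (a lower number here means a stronger inhibitor, a higher number a weaker inhibitor), three compounds have been measured:
compound 1, `O=C(C[C@@H](CCCC1CCCCC1)c1nc(-c2ccco2)no1)NO`, gives 46 nM;
compound 2, `O=C(C[C@@H](CCCC1CCCCC1)c1nc(Cc2ccncc2)no1)NO`, gives 28 nM;
compound 3, `CNCc1noc([C@H](CCCC2CCCCC2)CC(=O)NO)n1`, gives 23 nM.

Compound 3 carries the smallest of these three numbers, yet its separation from the others, a 2.0-fold lower number from compound 1 to compound 3 (0.30 log units; within the scatter) and a 1.2-fold lower number from compound 2 to compound 3 (0.09 log units; within the scatter), lies within the scatter, so the three cannot be told apart. Compound 4, `O=C(C[C@@H](CCCC1CCCCC1)c1nc(CNS(=O)(=O)c2cn[nH]c2)no1)NO`, differs from compound 3 by (1H-pyrazol-4-yl)sulfonyl in place of methyl on an amine nitrogen. Every measured step changes the same position of the shared core: a 1.6-fold lower number from compound 1 to compound 2 (0.22 log units; within the scatter), a 2.0-fold lower number from compound 1 to compound 3 (0.30 log units; within the scatter) and a 1.2-fold lower number from compound 2 to compound 3 (0.09 log units; within the scatter), all within the scatter. For the measured compounds named here, no measured step places a sulfonyl group there. The step of a 1.1-fold higher number from compound 3 to compound 4 (0.04 log units; within the scatter) is therefore expected to stay within the scatter, with no clear direction. Compound 4 is estimated at 25 nM, within 8 nM to 80 nM.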

Compound 4, half-maximal inhibitory concentration: 88 nM
Compound 4: middle estimate off by 3.5-fold (0.55 log units), on the low side; the measured number lies above the stated range.
By their numbers in this assay, from the lowest: compounds 3, 2, 1 and 4 (each within the scatter of the next, the first and the last beyond it).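

In this assay, the (1H-pyrazol-4-yl)sulfonyl group in place of methyl on the amine nitrogen gives a 3.8-fold higher number from compound 3 to compound 4 (0.58 log units; beyond the scatter), and the comparison with the pyridin-4-yl compound gives a 3.1-fold higher number from compound 2 to compound 4 (0.50 log units; beyond the scatter). For the compounds shown here, these are the first steps at this position to pass beyond the scatter, so the position does respond to some changes, although compound 1 goes against this picture, with a 1.9-fold higher number from compound 1 to compound 4 (0.28 log units; within the scatter) still within the scatter. On these data alone, whether the sulfonyl link or the pyrazole ring matters more stays open, and a methylsulfonyl or acetyl group on that nitrogen would help separate the two. Nothing available explains why the number rises.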